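A few compounds are considered here, and "the series" means these few. Any claim that something is new, unique, unknown or untested is made for them only; others in the source may bear on it.

In a functional assay on MCF7 cells (Breast, Homo sapiens) for inhibition (on this read-out lower numbers stand for stronger inhibition of growth and higher numbers for weaker inhibition of growth), compound 1 `Nc1ccc(-c2nc3ccc(F)cc3s2)cc1Cl` gives < 10 nM, which is a limit of the assay and not an exact number. Compound 2 `Cc1cc(-c2nc3cccc(F)c3s2)ccc1N` gives < 10 nM, which is also a limit. The whole picture so far is therefore (the limit of < 10 nM in this assay, at which 2 of the 2 values shown sit), so the data show that both compounds reach the limit but cannot place either one more exactly.

Compound 3 `Cc1cc(-c2nc3ccc(F)cc3s2)ccc1N` keeps the core of compound 1 but has methyl in place of chloro on an aromatic carbon, ortho to an amino group: methyl in place of chloro on an aromatic carbon. Going by the values given here, no measured pair shows this swap on its own, so there is no direct guide to its size. Compound 2 also carries methyl, and its < 10 nM is a limit as well. In this assay, no step beyond the usual scatter is expected in either direction, and another limit would be no surprise. The estimated change is a step that the limit leaves unreadable from compound 1 to compound 3. For compound 3, the expected value is 5 nM, with an estimated range from 1 nM to 10 nM.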

Compound 3, concentration for 50% growth inhibition: < 10 nM
Compound 3: a limit, no number (the forecaster's own chance of this, stated with the estimate: 75%); the middle value does not contradict the limit.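

In this assay compound 3 gives < 10 nM, which is a limit of the assay and not a number. Compound 1 also sits at a limit, so no step can be read between compound 1 and compound 3. The compounds shown leave open how strongly each one truly acts and whether methyl in place of chloro changes anything: the limit of < 10 nM in this assay, at which 3 of the 3 values shown sit.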